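A few compounds are considered here, and "the series" means these few. Any claim that something is new, unique, unknown or untested is made for them only; others in the source may bear on it.

Within the series compound 3 `CCOc1nc2nc(C)cc(Nc3ccc(S(F)(F)(F)(F)F)cc3)n2n1` gives the lowest value in a physicochemical assay for solubility, at pH 6.5; a higher number here means a more soluble compound, a lower number a less soluble compound: compound 3 shows 4000 nM. Compound 2 `Cc1cc(Nc2ccc(S(F)(F)(F)(F)F)cc2)n2nc(C3CC3)nc2n1` stands nearest, with compound 2 at 16000 nM, a step of a 4.0-fold lower number from compound 2 to compound 3 (0.60 log units; beyond the scatter). Compound 1 `COCc1nc2nc(C)cc(Nc3ccc(S(F)(F)(F)(F)F)cc3)n2n1` stands furthest, compound 1 giving 63000 nM, a step of a 16-fold lower number from compound 1 to compound 3 (1.20 log units; beyond the scatter). The step of a 3.9-fold lower number from compound 1 to compound 2 (0.60 log units; beyond the scatter) completes the three.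

Compound 4 `Cc1cc(Nc2ccc(S(F)(F)(F)(F)F)cc2)n2nc(C(F)(F)F)nc2n1` follows from compound 3 by trifluoromethyl in place of ethoxy on an aromatic carbon. Among the compounds with values here, no measured step involves trifluoromethyl at this position, so the three steps bear only indirectly: they show that exchanging the group on this aromatic carbon shifts this assay by modest to large amounts, and compound 3 already sits at the low end. A further step in either direction is possible; no clear direction can be read from the three steps. Compound 4 is therefore expected to land close to compound 3, the step of a 1.3-fold lower number from compound 3 to compound 4 (0.12 log units; within the scatter) being the estimate, with a wide range. Compound 4 is estimated at 3000 nM, between 1000 nM and 12000 nM.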

Compound 4, solubility: 30000 nM
Estimate against measurement, compound 4: 10-fold (1.00 log units) below; the measured number lies above the stated range.
By their numbers in this assay, from the lowest: compound 3; then compounds 2 and 4 (each within the scatter of the next); then compound 1.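

In this assay trifluoromethyl on this aromatic carbon moves the read-out up from ethoxy (a 7.5-fold higher number from compound 3 to compound 4 (0.88 log units; beyond the scatter)) and cannot be separated from cyclopropyl (a 1.9-fold higher number from compound 2 to compound 4 (0.27 log units; within the scatter)), leaving compound 3 alone at the low end. Methoxymethyl stays only just apart from trifluoromethyl (a 2.1-fold lower number from compound 1 to compound 4 (0.32 log units; beyond the scatter)); ethoxy and methoxymethyl both carry oxygen yet mark the two ends of the four compounds, so oxygen in the group does not by itself track the read-out here. No measurement at hand gives a reason for any of these steps.

Open, going by these compounds, is whether an amine, a carboxylic acid or a longer ether chain on this aromatic carbon would fall inside the span of these four compounds. Also open, on these data alone, is whether the same order of groups holds when another part of the shared core changes.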